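Carboxybenzyl for carboxyphenylcarbonyl on the ring nitrogen

A few compounds are considered here, and "the series" means these few. Any claim that something is new, unique, unknown or untested is made for them only; others in the source may bear on it.

Measured so far:
compound 1 `CC(C)c1onc(-c2c(Cl)cccc2Cl)c1COc1ccc(N(C)C(=O)c2cccc(C(=O)O)c2)c(C(F)(F)F)n1`, 537 nM
compound 2 `Cc1cc(C(F)(F)F)cc(OCc2c(-c3c(Cl)cccc3Cl)noc2C(C)C)n1`, "not active" (no number reported)

Among the measured compounds shown here, compound 1 is the only member of the series with a number in a functional assay on HEK293 cells for agonist activity at Bile acid receptor (Homo sapiens), read by a luciferase reporter; on this read-out lower numbers stand for an effect already at smaller amounts and higher numbers for an effect only at larger amounts of compound; compound 2 is reported in this assay as "not active" (no number reported), without a number, so no step between measured compounds can be stated. Compound 1 therefore stands alone as the reference point.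

Compound 3 `CC(C)c1onc(-c2c(Cl)cccc2Cl)c1COc1ccc(N(C)Cc2cccc(C(=O)O)c2)c(C(F)(F)F)n1` keeps the shared core of compound 1 and changes one place: 3-carboxybenzyl in place of (3-carboxyphenyl)carbonyl on a nitrogen on an aromatic ring. The carbonyl between the ring nitrogen and the carboxyphenyl ring is lost; the acid and the aromatic ring remain.

For the measured compounds named here, no measured pair shows what this change does. The expectation rests only on compound 1, whose value of 537 nM sets the starting level. A step beyond the usual scatter is expected, in the direction of an effect only at larger amounts, since the carbonyl that joins the acid-bearing ring to the nitrogen in compound 1 is removed; the size is uncertain. For compound 3 the estimate in this assay is 1500 nM, range 300 nM to 8000 nM, a step of a 2.8-fold higher number from compound 1 to compound 3 (0.45 log units; beyond the scatter) from compound 1.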

Compound 3, half-maximal effective concentration: 6 nM
Compound 3: middle estimate off by 250-fold (2.40 log units), on the high side; the whole stated range lies above it.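

In this assay the swap of (3-carboxyphenyl)carbonyl for 3-carboxybenzyl on a nitrogen on an aromatic ring gives a 90-fold lower number from compound 1 to compound 3 (1.95 log units; beyond the scatter) in a single change, so this position responds strongly to how the acid-bearing ring is attached to the nitrogen. The carboxylic acid and the aromatic ring are present on both sides of this pair, which places the large step on the change in the attachment and not on the loss of either of them, something compound 2, without a number, could not show. No measurement on hand accounts for the step, and its cause remains unassigned.

On these data alone, all of this rests on one pair, so it remains open whether the step would hold on another core or with another substituent on the nitrogen in place of methyl. Also open, as far as these compounds go, is how a longer chain, such as 2-(3-carboxyphenyl)ethyl, would compare with 3-carboxybenzyl, and whether a tetrazole or a primary amide could stand in for the carboxylic acid on the benzyl ring.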